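Working notes: chloro to bromo, compound 3 to compound 4

A few compounds are considered here, and "the series" means these few. Any claim that something is new, unique, unknown or untested is made for them only; others in the source may bear on it.

Measured so far:
compound 1 `NC(=O)c1c(Nc2ccc(I)cc2F)cc(F)cc1Oc1cccc(NS(N)(=O)=O)c1` — 180 nM
compound 2 `NC(=O)c1c(Nc2ccc(I)cc2F)cc(F)cc1Oc1ccc(F)c(NS(N)(=O)=O)c1` — 2510 nM
compound 3 `NC(=O)c1c(Nc2ccc(I)cc2F)cc(F)cc1Oc1cccc(NS(N)(=O)=O)c1Cl` — 87 nM

In a functional assay on HCT-116 cells (Homo sapiens) for antiproliferative activity (a higher number here means a weaker inhibitor, a lower number a stronger inhibitor), compound 3 gives the lowest number of the three; compound 1 sits closest, compound 2 furthest. The measured steps show that a fluoro on the aryl ether ring costs much: a 14-fold higher number from compound 1 to compound 2 (1.14 log units; beyond the scatter). A chloro at the position of compound 3 helps modestly: a 2.1-fold lower number from compound 1 to compound 3 (0.32 log units; beyond the scatter).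

Compound 4 `NC(=O)c1c(Nc2ccc(I)cc2F)cc(F)cc1Oc1cccc(NS(N)(=O)=O)c1Br` carries bromo in place of chloro on an aromatic carbon. Among the measured compounds shown here, the only step that bears on this is the one from compound 1 to compound 3, modest in size; no measured pair exchanges one halogen for another. The expectation is therefore a small step from compound 3 to compound 4, if any, within the scatter: a 1.1-fold lower number from compound 3 to compound 4 (0.04 log units; within the scatter). Compound 4 is estimated at 80 nM, between 35 nM and 200 nM.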

Compound 4, half-maximal inhibitory concentration: 152 nM
Compound 4: middle estimate off by 1.9-fold (0.28 log units), on the low side, and the stated range covers the measured number.
By their numbers in this assay, from the lowest: compounds 3, 4 and 1 (each within the scatter of the next, the first and the last beyond it); then compound 2.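

In this assay, this position, ortho to a sulfamoylamino group, now shows a halogen exchange: a 1.7-fold higher number from compound 3 to compound 4 (0.24 log units; within the scatter) lies within the scatter, so bromo and chloro cannot be told apart here. Bromo also cannot be told apart from hydrogen, with a 1.2-fold lower number from compound 1 to compound 4 (0.07 log units; within the scatter) likewise within the scatter, so the modest gain seen with chloro is not clearly shared by bromo. Nothing available bears on a cause for this result. Still open is how a methyl or methoxy group would read at this position, where only hydrogen, chloro and bromo are shown.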